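Triazole substituent swap in the chloroquinoline series

The source may report more compounds than this note shows. Statements on the series, on what has been measured and on what is new or still open speak of the compounds shown alone.

Two compounds of the series have numbers in a functional assay on NCI-H460 cells (Homo sapiens) for antiproliferative activity, read by sulforhodamine B assay, with a stated time of 72 h; a lower number here means a stronger inhibitor, a higher number a weaker inhibitor. Compound 1 `CN(CCNCc1cn(-c2ccccc2)nn1)CCNc1ccnc2cc(Cl)ccc12` gives 25000 nM in this assay. Among the measured compounds shown here, compound 2 `CN(CCNCc1cn(Cc2ccc(Br)cc2)nn1)CCNc1ccnc2cc(Cl)ccc12` gives 12000 nM in this assay and so stands at the lower of the two numbers, with compound 1 the nearest neighbour; the one measured step, a 2.1-fold lower number from compound 1 to compound 2 (0.32 log units; beyond the scatter), is modest but beyond the scatter.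

Compound 3 `CN(CCNCc1cn(CCC(=O)Nc2ccccn2)nn1)CCNc1ccnc2cc(Cl)ccc12` is not yet measured. It differs from compound 2 in one place: ((pyridin-2-yl)carbamoyl)methyl in place of 4-bromophenyl on a saturated chain carbon bound to an aromatic nitrogen. The 4-bromophenyl that distinguished compound 2 from compound 1 is gone, and in its place stands a group that carries an amide and a pyridine ring.

For the measured compounds named here, the only step that bears on this position is a 2.1-fold lower number from compound 1 to compound 2 (0.32 log units; beyond the scatter), and it shows that altering the group on the triazole nitrogen moves this assay by a small amount. Going by the values given here, no measured pair covers an amide or a pyridine at this site, so the direction is open. A step near the scatter, a 1.5-fold higher number from compound 2 to compound 3 (0.18 log units; within the scatter), is expected, leaning toward a somewhat higher number given that the gain seen in a 2.1-fold lower number from compound 1 to compound 2 (0.32 log units; beyond the scatter) came with the 4-bromophenyl now removed. Compound 3 is therefore estimated at 18000 nM, within 6000 nM to 50000 nM.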

Compound 3, half-maximal inhibitory concentration: > 200000 nM
Compound 3: a limit, no number (the forecaster's own chance of this, stated with the estimate: 10%); middle value at least 11-fold (1.04 log units) from the limit.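

Compound 3 stands as a limit, not a number, in this assay: the limit of > 200000 nM in this assay, at which 1 of the 3 values shown sits.

The earlier pair showed only a 2.1-fold lower number from compound 1 to compound 2 (0.32 log units; beyond the scatter), whereas the 2-((pyridin-2-yl)carbamoyl)ethyl group on the aromatic nitrogen brings an at least 16-fold higher number from compound 2 to compound 3 (1.22 log units; beyond the scatter) and an at least 8.0-fold higher number from compound 1 to compound 3 (0.90 log units; beyond the scatter). This position is therefore far from indifferent to what it carries: phenyl and 4-bromobenzyl both give a measured number in this assay, the chain with its amide and pyridine ring gives only a limit, and each step to compound 3 is a lower bound on its size.

The change removes the 4-bromophenyl and brings in the amide, the pyridine ring and a different chain all at once, so the compounds shown do not tell which of these parts carries the step. As far as these compounds go, an unsubstituted benzyl, a plain alkyl chain, or the same chain ending in a phenyl amide or a carboxylic acid would separate these parts, and how far the number for compound 3 lies beyond its limit also stays open.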